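Amide substituent change on the shared core, working notes

The compounds below may be only part of what the source reports. "The series", "measured", "known", "first", "only" and "open" are said of these compounds alone.

Three amides of the shared core have readings so far. In an ADME assay on MRC5 cells (Homo sapiens) for inhibition, with a stated time of 72 h (a lower number here means that less compound is needed, a higher number that more compound is needed for the effect), compound 1 (`COc1cccc(OC)c1C(=O)Nc1c[nH]nc1C(=O)NC1CC1`) gives > 50000 nM as a limit and not a number. In this assay compound 2 (`COc1cccc(OC)c1C(=O)Nc1c[nH]nc1C(=O)NCCCOC(C)C`) gives > 50000 nM as a limit and not a number. In this assay compound 3 (`COc1cccc(OC)c1C(=O)Nc1c[nH]nc1C(=O)Nc1ccccc1`) gives > 50000 nM as a limit and not a number, so its standing in the series has no numerical value. Within the data shown here, the series so far shows the limit of > 50000 nM in this assay, at which 3 of the 3 values shown sit, and nothing finer.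

The change to compound 4 (`COc1cccc(OC)c1C(=O)Nc1c[nH]nc1C(=O)NCc1ncccc1C`) is (3-methylpyridin-2-yl)methyl in place of phenyl on an amide-type nitrogen and in words puts (3-methylpyridin-2-yl)methyl in place of phenyl on an amide-type nitrogen.

Three measured changes at that same place bear on it: a step that the two limits leave unreadable from compound 1 to compound 3 and a step that the two limits leave unreadable from compound 2 to compound 3 and a step that the two limits leave unreadable from compound 1 to compound 2 and none of them gives a size to carry over. The starting point is compound 3 with its limit of > 50000 nM as the only reference, and no step beyond the scatter is expected in this assay on this evidence. The expected change is a number no higher from compound 3 to compound 4 (the limit leaves the size open) as an estimate only. For compound 4 the estimated value is 50000 nM with an expected range from 20000 nM to 100000 nM and a further limit is the likeliest report.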

Compound 4, half-maximal effective concentration: > 50000 nM
Compound 4: no number, only a limit; the forecaster's own chance of this, stated with the estimate: 85%; the middle value sits exactly at the limit.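

In this assay, among these compounds, compound 4 gives > 50000 nM, a limit and not a number, so no step from compound 1, compound 2 or compound 3 to compound 4 can be read. The series remains at a single reading: the limit of > 50000 nM in this assay, at which 4 of the 4 values shown sit.

The compounds shown leave open how these four amides compare with one another and whether any amide substituent on the shared core gives a number in this assay.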